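The source may report more compounds than this note shows. Statements on the series, on what has been measured and on what is new or still open speak of the compounds shown alone.

Compounds measured so far:
compound 1 `N#C/C=C\[C@H]1O[C@@H](n2cnc3c(N)ncnc32)[C@H](O)[C@@H]1O` — > 20 ug/mL
compound 2 `N#C/C=C/[C@H]1O[C@@H](n2cnc3c(N)ncnc32)[C@H](O)[C@@H]1O` — 11 ug/mL

Compound 1 `N#C/C=C\[C@H]1O[C@@H](n2cnc3c(N)ncnc32)[C@H](O)[C@@H]1O` is described here only by a limit of the assay: in a functional assay on HEL cells (Homo sapiens) for cytotoxicity (on this read-out lower numbers stand for higher toxicity in this test and higher numbers for lower toxicity in this test), compound 1 gives > 20 ug/mL. For the measured compounds named here, compound 2 `N#C/C=C/[C@H]1O[C@@H](n2cnc3c(N)ncnc32)[C@H](O)[C@@H]1O` gives 11 ug/mL in this assay, the only number among the values shown. Going by the values given here, the one measured step runs an at least 1.8-fold lower number from compound 1 to compound 2 (0.25 log units; that floor lies within the scatter), and the two compounds differ only in configuration as drawn (the fact that compounds 1 and 2 differ only in the configuration as drawn), with one end of that step resting on the limit (the limit of > 20 ug/mL in this assay, at which 1 of the 2 values shown sits).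

Compound 3 `N#C/C(Cl)=C\[C@H]1O[C@@H](n2cnc3c(N)ncnc32)[C@H](O)[C@@H]1O` is not yet measured. It differs from compound 2 by a group of 5 heavy atoms (3 carbon, 1 nitrogen, 1 chlorine; no ring) in place of a group of 4 heavy atoms (3 carbon, 1 nitrogen; no ring), on a saturated ring carbon. Among the compounds with values here, the single measured step is a change of configuration of the double bond and does not bear on an exchange of one group for another on a saturated ring carbon, so no measured step speaks directly to this change. Compound 3 is therefore expected to sit near compound 2, with a step of a 1.1-fold lower number from compound 2 to compound 3 (0.04 log units; within the scatter) that need not exceed the scatter. The estimate for compound 3 in this assay is 10 ug/mL, within 4 ug/mL to 25 ug/mL.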

Compound 3, half-maximal cytotoxic concentration: 1.2 ug/mL
Estimate against measurement, compound 3: 8.3-fold (0.92 log units) above, outside the stated range (below it).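

In this assay, for the compounds shown here, the exchange of the 2-cyanoethenyl group for the chlorine-bearing group on the saturated ring carbon next to the ring oxygen gives a 9.2-fold lower number from compound 2 to compound 3 (0.96 log units; beyond the scatter), which shows that this position responds to a change of the group it carries, something the single change of configuration could not show. Compound 3 has the lowest number of the three compounds, and its step from the other double-bond form is an at least 16-fold lower number from compound 1 to compound 3 (1.22 log units; beyond the scatter). That second step gives only a floor for the size of the change, since one of its ends is a limit of the assay and not a number: the limit of > 20 ug/mL in this assay, at which 1 of the 3 values shown sits.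

The compounds shown do not tell whether the chlorine itself matters or whether another substituent at that carbon of the chain, such as bromine, fluorine or a methyl group, would lower the number in the same way. They also leave open how the configuration of the double bond acts once the chlorine is present, and whether a carboxylic acid or an amide in place of the nitrile would keep the lower number.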